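The source may report more compounds than this note shows. Statements on the series, on what has been measured and on what is new or still open speak of the compounds shown alone.

Of the compounds shown here, three built on one shared core have been measured in an assay on cells for binding affinity to Cyclin-C/Cyclin-dependent kinase 19 (Homo sapiens), read by LanthaScreen; a higher number here means a weaker inhibitor, a lower number a stronger inhibitor. Compound 1 `Cn1ncc2cc(-c3cnc4[nH]ccc4c3N3CCC4(CCNC4=O)CC3)ccc21` gives 7 nM, compound 2 `O=C1NCCC12CCN(c1c(-c3ccc4scnc4c3)cnc3[nH]ccc13)CC2` gives 14 nM, and compound 3 `Cn1cnc2ccc(-c3cnc4[nH]ccc4c3N3CCC4(CCNC4=O)CC3)cc21` gives 11 nM. Compound 3 sits close to both others: the steps of a 1.6-fold higher number from compound 1 to compound 3 (0.20 log units; within the scatter) and a 1.3-fold lower number from compound 2 to compound 3 (0.10 log units; within the scatter) are within the scatter, as is a 2.0-fold higher number from compound 1 to compound 2 (0.30 log units; within the scatter). Compound 4 `O=C1NCCC12CCN(c1c(-c3ccc4ncsc4c3)cnc3[nH]ccc13)CC2` differs from compound 3 in one place: 1,3-benzothiazol-6-yl in place of 1-methyl-1H-benzimidazol-6-yl on an aromatic carbon. The closest comparison already seen is the exchange of a 1,3-benzothiazol-5-yl for the benzimidazole, a 1.3-fold lower number from compound 2 to compound 3 (0.10 log units; within the scatter), which stayed within the scatter, so no step beyond the scatter is expected here either. For compound 4 the expected value in this assay is 12 nM, with a range from 6 nM to 25 nM. This estimate for compound 4 means a step of a 1.1-fold higher number from compound 3 to compound 4 (0.04 log units; within the scatter).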

Compound 4, half-maximal inhibitory concentration: 80 nM
Estimate against measurement, compound 4: 6.7-fold (0.82 log units) below, outside the stated range (above it).
By their numbers in this assay, from the lowest: compounds 1, 3 and 2 (each within the scatter of the next); then compound 4.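

The attachment point of the benzothiazole matters at this position in this assay: with the same group joined through a different ring carbon, the change from 1,3-benzothiazol-5-yl to 1,3-benzothiazol-6-yl gives a 5.7-fold higher number from compound 2 to compound 4 (0.76 log units; beyond the scatter). The earlier compounds stayed within the scatter of one another, but this position does distinguish between fused aromatic groups, as shown by a 7.3-fold higher number from compound 3 to compound 4 (0.86 log units; beyond the scatter) and an 11-fold higher number from compound 1 to compound 4 (1.06 log units; beyond the scatter). No measurement available here accounts for this loss of strength. Left open is whether a single-ring group such as phenyl or pyridinyl at this position would give a number like that of compound 3 or like that of compound 4.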